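The source may report more compounds than this note shows. Statements on the series, on what has been measured and on what is new or still open speak of the compounds shown alone.

Measured so far:
compound 1 `CN(C)CCN1CCN(c2nc(-c3ccccn3)nc3c2CN(Cc2ccccc2)CC3)CC1` — 57%
compound 2 `CN(C)CCN1CCN(c2nc(-c3ccccn3)nc3c2CN(Cc2ccc(F)cc2)CC3)CC1` — "not active" (no number reported)
compound 3 `Fc1ccc(CN2CCc3nc(-c4ccccn4)nc(NCCN4CCCC4)c3C2)cc1` — 40.6%

In an assay on A549 cells with Cystic fibrosis transmembrane conductance regulator variant F508del (Homo sapiens) as the target, read by fluorescence, with a stated time of 25 min (on this read-out higher numbers stand for larger maximal responses and lower numbers for smaller maximal responses), compound 1 gives 57%. Compound 2 is reported in this assay only as "not active" (no number reported), with no number attached, so it stands on no single value and cannot be set against compound 1 or compound 3 by size. Compound 3 carries the same 4-fluorobenzyl group as compound 2 but a different side chain; in this assay compound 3 gives 40.6%.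

The account now follows the step from compound 2 to compound 4 `CN(C)CCN1CCN(c2nc(-c3ccccn3)nc3c2CN(CC2CCCCC2)CC3)CC1`, in which the change is cyclohexyl in place of 4-fluorophenyl on a saturated chain carbon bound to an amine nitrogen in a ring. For the measured compounds named here, no step between measured compounds is available, and none of the measured compounds carries cyclohexylmethyl, so the size and direction of the step in this assay cannot be read from anything measured here; a step of either sign beyond the scatter is possible, and so is none. Against that background, compound 4 is expected to give about 30% in this assay, with an estimated range from 0% to 60%.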

Compound 4, largest response reached (Emax), in percent of the reference or control that the assay uses: "not active" (no number reported)
Nothing numeric was reported for compound 4; no gap can be computed for the estimate.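

For the compounds shown here, compound 2 and compound 4 are both reported only as "not active" in this assay, so no step between them can be read. Nothing shown here bears on this result. The compounds shown leave open how cyclohexylmethyl compares with 4-fluorobenzyl in size of response.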